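Restoring a Small Alkyl Group on the Pyrimidine Ring

The source may report more compounds than this note shows. Statements on the series, on what has been measured and on what is new or still open speak of the compounds shown alone.

Compound 1 `Cc1cnc(N2CCC(c3coc4c(N5CCc6cc(S(C)(=O)=O)ccc65)ncnc34)CC2)nc1` is a strong agonist: in a functional assay on cells for agonist activity at Glucose-dependent insulinotropic receptor (Homo sapiens), read by a luciferase reporter, with a stated time of 4 h (on this read-out lower numbers stand for smaller maximal responses and higher numbers for larger maximal responses), compound 1 gives 159%. Compound 2 `CC(=O)c1cnc(N2CCC(c3coc4c(N5CCc6cc(S(C)(=O)=O)ccc65)ncnc34)CC2)nc1` carries an acetyl on the aromatic carbon where compound 1 has a methyl, and in this assay compound 2 gives 12%. The step of a number 147 percentage points lower from compound 1 to compound 2 (beyond the scatter) is the only one measured, and it leaves compound 2 as the lowest of the two compounds shown, with compound 1 far above it.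

Compound 3 `CCc1cnc(N2CCC(c3coc4c(N5CCc6cc(S(C)(=O)=O)ccc65)ncnc34)CC2)nc1` differs from compound 2 in one place: ethyl in place of acetyl on an aromatic carbon. The acetyl leaves, and an ethyl, which like the methyl of compound 1 has no hydrogen-bond acceptor, enters. Within the data shown here, the one step that bears on this is the large drop from compound 1 to compound 2 on adding the acetyl; its removal is therefore expected to reverse much of that loss. Compound 3 is expected to give 130%, within 60% to 175%, in this assay. This amounts to an expected step of a number 118 percentage points higher from compound 2 to compound 3 (beyond the scatter).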

Compound 3, largest response reached (Emax), in percent of the reference or control that the assay uses: 154%
For compound 3 the middle estimate is 24 percentage points below the measured one; measured number inside the range.
By their numbers in this assay, from the lowest: compound 2; then compounds 3 and 1 (each within the scatter of the next).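

In this assay, swapping the acetyl for ethyl gives a number 142 percentage points higher from compound 2 to compound 3 (beyond the scatter), so the low response of compound 2 is tied to the acetyl and is not a general feature of substitution on this aromatic carbon. The change from methyl to ethyl gives a number 5 percentage points lower from compound 1 to compound 3 (within the scatter), which means that this read-out does not separate the two alkyl groups and that the added chain carbon costs no measurable maximal response. Nothing available here accounts for the loss seen with the acetyl.

The compounds shown leave open whether a longer chain such as propyl would keep the response on this carbon, and whether a methoxy group or an amine would behave like the ethyl or like the acetyl. They also leave open whether a hydroxyethyl group, which lacks the carbonyl of the acetyl, would restore the response.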